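The compounds below may be only part of what the source reports. "The series", "measured", "known", "first", "only" and "open" are said of these compounds alone.

Compounds measured in a functional assay on the whole organism with Mus musculus as the target, in the writhing test; a higher number here means that more compound is needed for the effect, a lower number that less compound is needed:

Compound 2, `Cc1cc(=O)oc2nn(C(C)C)c(C)c12`: 35.3 mg/kg
Compound 1, `CCN(CC)CCn1nc2oc(=O)cc(C)c2c1C`: 100 mg/kg
Compound 3, `CCCCCn1nc(C)c2c(C)cc(=O)oc21`: > 100 mg/kg

Compound 2 has the lowest of the two numbers that were read as numbers in this assay; compound 1 sits a good way above it, beyond the usual scatter. The value for compound 3 is a limit of the assay and not a number, so it can only be read as the limit of > 100 mg/kg in this assay, at which 1 of the 3 values shown sits.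

Compound 4, `CCCn1nc2oc(=O)cc(C)c2c1C`, is the compound still to be measured. It differs from compound 2 in one place: propyl in place of isopropyl on an aromatic nitrogen. The chain keeps its size; only its branching changes from a branched to a straight arrangement.

Among the measured compounds shown here, no measured pair shows a change of exactly this kind, so the expectation rests on the spread of the three values and on the small size of the change. A modest loss is expected, with the step from compound 2 to compound 4 estimated at a 1.6-fold higher number from compound 2 to compound 4 (0.19 log units; within the scatter). Compound 4 is therefore expected to give about 55 mg/kg in this assay, likely between 22 mg/kg and 130 mg/kg.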

Compound 4, dose for half-maximal effect: 72.6 mg/kg
Compound 4: the middle estimate sits 1.3-fold (0.12 log units) below what was measured; measured number inside the range.
By their numbers in this assay, from the lowest: compound 2; then compounds 4 and 1 (each within the scatter of the next).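

In this assay, among the compounds shown here, this pair gives the first direct reading at the aromatic nitrogen, and it shows that branching alone can shift the result: a 2.1-fold higher number from compound 2 to compound 4 (0.31 log units; beyond the scatter). Isopropyl and propyl have the same count of heavy atoms, so this modest step comes from how those atoms are joined, not from how many there are. On the chain itself, methyl in place of diethylamino, two bonds along the chain from an aromatic nitrogen, gives no difference that can be told from the scatter: a 1.4-fold lower number from compound 1 to compound 4 (0.14 log units; within the scatter).

The compounds shown leave open how a longer branched chain, a cyclopropyl ring or a carboxylic acid on this nitrogen would compare with isopropyl. Compound 3 gives a limit and not a number, so it adds no step here: the limit of > 100 mg/kg in this assay, at which 1 of the 4 values shown sits.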